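Phenoxy extension of the fluoro analogue: cytotoxicity outlook

A few compounds are considered here, and "the series" means these few. Any claim that something is new, unique, unknown or untested is made for them only; others in the source may bear on it.

Compound 1 `NS(=O)(=O)c1ccc(N2N=C(c3ccccc3)CC2c2ccccc2F)cc1` gives 28000 nM in an ADME assay on Vero 76 cells (Chlorocebus sabaeus) for cytotoxicity, read by MTT assay, with a stated time of 96 h (a higher number here means that more compound is tolerated, a lower number that less compound is tolerated), the higher of the two numbers measured; compound 2 `NS(=O)(=O)c1ccc(N2N=C(c3ccccc3)CC2c2ccccc2Cl)cc1` gives 26000 nM, and the step of a 1.1-fold lower number from compound 1 to compound 2 (0.03 log units; within the scatter) lies within the scatter. Compound 3 `NS(=O)(=O)c1ccc(N2N=C(c3ccc(Oc4ccccc4)cc3)CC2c2ccccc2F)cc1` carries a phenoxy in place of hydrogen on an aromatic carbon. Within the data shown here, no measured step involves this change; the only step known concerns a halogen exchange and does not bear on it. For compound 3 a step of a 1.3-fold lower number from compound 1 to compound 3 (0.10 log units; within the scatter) is therefore expected, not beyond the scatter. Compound 3 is estimated at 22000 nM, with a range of 8000 nM to 60000 nM.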

Compound 3, half-maximal cytotoxic concentration: 96000 nM
The estimate for compound 3 lay 4.4-fold (0.64 log units) below the measured number; the measured number lies above the stated range.
By their numbers in this assay, from the lowest: compounds 2 and 1 (each within the scatter of the next); then compound 3.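

In this assay, phenoxy in place of hydrogen on an aromatic carbon, para to a large group, gives a 3.4-fold higher number from compound 1 to compound 3 (0.54 log units; beyond the scatter), so this position takes a large aromatic group with more compound tolerated, whereas the halogen exchange stayed within the scatter. Nothing measured here accounts for this rise.

Going by these compounds, whether a methoxy group or a carboxylic acid at this position would move the number the same way stays open. Also open, on these data alone, is whether phenoxy has the same effect alongside the chloro group of compound 2.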